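The source may hold more compounds than are shown below. What is called first, only, known or untested is meant among the compounds shown, and "the series" means these compounds.

Compound 2, with the structure `O=C(NC1CCCCC1)N1CCN(C(=S)SCc2cn(Cc3ccccc3F)nn2)CC1`, was tested in a functional assay on EC9706 cells (Homo sapiens) for cytotoxicity, read by MTT assay, with a stated time of 72 h (a lower number here means a stronger inhibitor, a higher number a weaker inhibitor), and gives 84900 nM. Its companion compound 1, with the structure `CC(C)(C)NC(=O)N1CCN(C(=S)SCc2cn(Cc3ccccc3F)nn2)CC1`, gives 87800 nM in this assay. Among the compounds with values here, the only comparison available, a 1.0-fold lower number from compound 1 to compound 2 (0.01 log units; within the scatter), concerns the other end of the shared core, where cyclohexyl replaced tert-butyl on an amide-type nitrogen, and it made no difference beyond the scatter. Compound 2 therefore stands on numbers that cannot be told apart from those of compound 1.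

Compound 3, with the structure `O=C(NC1CCCCC1)N1CCN(C(=S)SCc2cn(Cc3ccc(F)cc3)nn2)CC1`, differs from compound 2 by a change at the far end of the molecule: 4-fluorophenyl in place of 2-fluorophenyl on a saturated chain carbon bound to an aromatic nitrogen. Within the data shown here, no measured step concerns a move of fluorine around that ring, so there is nothing in the data that speaks for a change in this assay in either direction. The expectation for compound 3 is therefore a step of about a 1.0-fold higher number from compound 2 to compound 3 (0.00 log units; within the scatter), meaning no change beyond the scatter. For compound 3 an estimate of 85000 nM is expected, within a range from 40000 nM to 180000 nM.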

Compound 3, half-maximal inhibitory concentration: > 128000 nM
Compound 3 gave a limit, no number; the forecaster's own chance of this, stated with the estimate: 10%; middle value at least 1.5-fold (0.17 log units) away from the limit.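

Compound 3 reached a limit of the assay and so has no number of its own: the limit of > 128000 nM in this assay, at which 1 of the 3 values shown sits. On a saturated chain carbon bound to an aromatic nitrogen, 4-fluorophenyl in place of 2-fluorophenyl, which uses the same atoms joined differently, gives an at least 1.5-fold higher number from compound 2 to compound 3 (0.17 log units; that floor lies within the scatter). The earlier pair of compound 1 and compound 2 spoke only for the other end of the molecule and had two real numbers to compare, whereas this step gives only a floor, so the true gap could lie within the scatter or well beyond it, and this first reading of the position cannot settle which.

Going by these compounds, how far the true value of compound 3 lies past its limit stays open, so the size of this change in this assay, and even whether it is a real change, remains unknown. Also open, on these data alone, is what this position would give with plain benzyl, without any fluorine, or with chlorine on the ring in place of fluorine, and whether any such group would bring a measurable number rather than another limit.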